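A few compounds are considered here, and "the series" means these few. Any claim that something is new, unique, unknown or untested is made for them only; others in the source may bear on it.

Working notes on a small series sharing one fused core, a 4-chlorophenylmethyl arm and a substituted phenyl ring, followed in a functional assay on HeLa cells (Homo sapiens) for cytotoxicity, with a stated time of 72 h; on this read-out higher numbers stand for weaker inhibition and lower numbers for stronger inhibition.

Compound 1 `Clc1ccc(Cc2nn3cc(-c4ccc(Br)cc4)nc3s2)cc1` returns in this assay only a limit, > 250000 nM. Compound 2 `O=[N+]([O-])c1ccc(-c2cn3nc(Cc4ccc(Cl)cc4)sc3n2)cc1` likewise gives in this assay a limit rather than a number, > 250000 nM. The step that the two limits leave unreadable from compound 1 to compound 2, nitro in place of bromo on an aromatic carbon, is therefore not readable in size or direction. Both values rest at the limit of > 250000 nM in this assay, at which 2 of the 2 values shown sit, and compound 2 stands exactly there: at the limit, with no measured number of its own.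

Compound 3 `N#CSc1c(-c2ccc([N+](=O)[O-])cc2)nc2sc(Cc3ccc(Cl)cc3)nn12` differs from compound 2 by cyanosulfanyl in place of hydrogen on an aromatic carbon. Among the compounds with values here, no measured step bears on this change; the single recorded step, from compound 1 to compound 2, alters the group on the phenyl ring, not the core, and is itself unreadable. The expectation for compound 3 in this assay therefore rests on compound 2 sitting at the limit and on the cyanosulfanyl group being a small addition. The step of an at least 2.0-fold lower number from compound 2 to compound 3 (0.31 log units; beyond the scatter) is estimated as modest, toward stronger inhibition but with a fair chance of another limit. Compound 3 is estimated at 120000 nM, within 15000 nM to 250000 nM.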

Compound 3, half-maximal inhibitory concentration: 16000 nM
The estimate for compound 3 lay 7.5-fold (0.88 log units) above the measured number; low and high end bracket the measured number.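

The change on the core does what the change on the phenyl ring could not: cyanosulfanyl in place of hydrogen, on the aromatic carbon next to the ring atom that bears the 4-nitrophenyl group, gives an at least 15-fold lower number from compound 2 to compound 3 (1.19 log units; beyond the scatter) in this assay. Compound 2 has only a limit in this assay, > 250000 nM, so the printed size of this step is a lower bound and not a measured difference. This position is therefore the first place in the series where a single change moves the read-out off the limit: the limit of > 250000 nM in this assay, at which 2 of the 3 values shown sit. Within the data shown here, compound 3, at 16000 nM, is the only compound here with a measured number.

The compounds shown leave open whether the whole cyanosulfanyl group is needed at this position, or whether a nitrile, a methylsulfanyl group or an amine there would give a similar number. They also leave open whether the same change would carry over to the bromo-substituted phenyl ring of compound 1, and the step between compound 1 and compound 2 cannot be read.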